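The source may report more compounds than this note shows. Statements on the series, on what has been measured and on what is new or still open speak of the compounds shown alone.

Working notes on the series. All three measured compounds share one core and differ only in the group on a single aromatic carbon. Compound 1 `Cc1ccccc1-n1nc(C)c2c1NC(=O)[C@H](C)S[C@@H]2c1ccc(-c2ccccc2)cc1` carries phenyl there and in an assay on isolated protein for agonist activity at Bile acid receptor (Homo sapiens), read by AlphaScreen, with a stated time of 30 min (a higher number here means that more compound is needed for the effect, a lower number that less compound is needed), compound 1 gives 990 nM. Compound 2 `COc1ccc(Oc2ccc([C@H]3S[C@@H](C)C(=O)Nc4c3c(C)nn4-c3ccccc3C)cc2)cc1` carries 4-methoxyphenoxy and in this assay compound 2 gives 2200 nM. Compound 3 `Cc1ccccc1-n1nc(C)c2c1NC(=O)[C@H](C)S[C@@H]2c1ccc(-c2ccsc2)cc1` carries thiophen-3-yl and in this assay compound 3 gives 1400 nM. Among these three numbers compound 3 holds the second highest; its nearest neighbour is reached by a 1.4-fold higher number from compound 1 to compound 3 (0.15 log units; within the scatter) and its furthest by a 1.6-fold lower number from compound 2 to compound 3 (0.20 log units; within the scatter), so all three values sit close together.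

Compound 4 `Cc1ccccc1-n1nc(C)c2c1NC(=O)[C@H](C)S[C@@H]2c1ccc(Oc2cccc(C(=O)O)c2)cc1` differs from compound 3 in one place: 3-carboxyphenoxy in place of thiophen-3-yl on an aromatic carbon. The step that bears most directly on this change is the one that puts an aryloxy group in place of a directly attached aryl, a 2.2-fold higher number from compound 1 to compound 2 (0.35 log units; beyond the scatter), a modest rise beyond the scatter. The exchange between thiophen-3-yl and 4-methoxyphenoxy, a 1.6-fold lower number from compound 2 to compound 3 (0.20 log units; within the scatter), stays within the scatter. No aryloxy bearing a carboxylic acid has been measured in this set, so the expectation leans on the aryloxy step alone. Compound 4 is therefore expected to show a modest rise, a 1.8-fold higher number from compound 3 to compound 4 (0.25 log units; within the scatter), in this assay. Compound 4 is estimated at 2500 nM, in the range 1000 nM to 6500 nM.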

Compound 4, half-maximal effective concentration: "not active" (no number reported)
No number was reported for compound 4; no gap can be computed for the estimate.
By their numbers in this assay, from the lowest: compounds 1, 3 and 2 (each within the scatter of the next, the first and the last beyond it).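

In this assay, for the compounds shown here, compound 4 is reported as not active with no number, so no step linking it to compound 1, compound 2 or compound 3 can be read. Nothing at hand bears on this result. The compounds shown leave open whether the result for compound 4 goes with the 3-carboxyphenoxy group specifically or with aryloxy groups more widely.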